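A few compounds are considered here, and "the series" means these few. Any claim that something is new, unique, unknown or untested is made for them only; others in the source may bear on it.

Compound 1, `COc1ccc(/C=C/c2cc(OC)c(OC)c(OC)c2-c2ccc(OC)cc2)cc1`, gives 36000 nM in a functional assay on SK-N-SH cells (Homo sapiens) for cytotoxicity, read by MTT assay, with a stated time of 48 h; on this read-out lower numbers stand for stronger inhibition and higher numbers for weaker inhibition.
Compound 2, `COc1ccc(/C=C/c2cc(OC)c(OC)c(OC)c2-c2ccccc2)cc1`, gives 11000 nM in this assay.
Compound 3, `C=C(c1ccc(OC)cc1)c1cc(OC)c(OC)c(OC)c1-c1ccccc1`, gives 31000 nM in this assay.

Compound 2 differs from compound 1 by hydrogen in place of methoxy on an aromatic carbon. That change gave a 3.3-fold lower number from compound 1 to compound 2 (0.51 log units; beyond the scatter). Compound 4, `C=C(c1ccccc1)c1cc(OC)c(OC)c(OC)c1-c1ccccc1`, has not yet been measured; it differs from compound 3 by hydrogen in place of methoxy on an aromatic carbon, the same change at the same place, made on a different core. How the core of compound 3 differs from the core of compound 1 is not broken down here. In this assay compound 3 and compound 1 lie within the scatter of each other, while compound 2 lies beyond it from both.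

Because the earlier change produced a 3.3-fold lower number from compound 1 to compound 2 (0.51 log units; beyond the scatter), a step of about that size is expected from compound 3 to compound 4, namely a 2.8-fold lower number from compound 3 to compound 4 (0.45 log units; beyond the scatter). The expectation rests on one measured pair only, and the cores differ, so the range is kept wide. Compound 4 is therefore estimated at 11000 nM in this assay, with a likely range from 4000 nM to 35000 nM.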

Compound 4, half-maximal inhibitory concentration: 34000 nM
The estimate for compound 4 lay 3.1-fold (0.49 log units) below the measured number; measured number inside the range.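

In this assay, hydrogen in place of methoxy on an aromatic carbon, read here as 4-methoxyphenyl to phenyl, gave a 1.1-fold higher number from compound 3 to compound 4 (0.04 log units; within the scatter), so the two cores did not respond alike to the same change: the same change on two cores in this assay, a 3.3-fold lower number (0.51 log units; beyond the scatter) from compound 1 to compound 2 and a 1.1-fold higher number (0.04 log units; within the scatter) from compound 3 to compound 4, 3.6-fold (0.56 log units) apart, beyond the scatter of two such steps

In this series, then, the step measured on the core of compound 1 could not be carried over to the core of compound 3, where the change left the number within the scatter. Within the data shown here, with only two matched pairs, however, the result does not show which feature of the two cores separates them, nor how the change would behave on any third core.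

The compounds shown carry only methoxy or hydrogen at this place, so it remains open how a hydroxyl, an amine or a carboxylic acid there would read on either core. Also open, going by these compounds, is whether replacing any of the three methoxy groups on the other ring, for example with hydroxyl, would alter the numbers.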